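Removing one aryl methyl in the hydroxypropyl amide series

The source may hold more compounds than are shown below. What is called first, only, known or untested is meant among the compounds shown, and "the series" means these compounds.

Measured so far in a functional assay on the whole organism with Mus musculus as the target, in the maximal electroshock model; a higher number here means that more compound is needed for the effect, a lower number that less compound is needed:
compound 1, `Cc1ccc(C23CCC(=O)N2CCCO3)c(C)c1`: > 150 mg/kg, a limit of the assay.
compound 2, `O=C(CCC(=O)c1ccc(Cl)c(Cl)c1)NCCCO`: 450 mg/kg.
compound 3, `Cc1ccc(C(=O)CCC(=O)NCCCO)c(C)c1`: > 150 mg/kg, a limit of the assay.

Compound 3 stands at the limit of this assay, with no number of its own; see (the limit of > 150 mg/kg in this assay, at which 2 of the 3 values shown sit). Only compound 2 carries an actual number in this assay. The next compound is compound 4, `Cc1ccc(C(=O)CCC(=O)NCCCO)cc1`, which differs from compound 3 by hydrogen in place of methyl on an aromatic carbon, ortho to a large group and meta to a methyl group. For the measured compounds named here, no measured pair shows such a change here, so a step within the usual scatter is expected, in no particular direction. Compound 4 is estimated at 300 mg/kg, between 150 mg/kg and 900 mg/kg; the expected step is a step that the limit leaves unreadable from compound 3 to compound 4.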

Compound 4, dose for half-maximal effect: > 300 mg/kg
Compound 4 gave a limit, no number; the forecaster's own chance of this, stated with the estimate: 60%; the middle value sits exactly at the limit.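

For the compounds shown here, compound 3 and compound 4 each give only a limit, so no step between them can be read. Left open is whether hydrogen in place of methyl on an aromatic carbon shifts the dose for half-maximal effect at all, in either direction.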